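Trimming the amide tail from phenylpropyl to butyl

This account rests on a few compounds, and the source may have more. Where it says the series, first, only, none or still open, it means among the compounds named here.

Compound 1, `COc1ccccc1N1CCN(CCCCNC(=O)c2ccc(N)cc2)CC1`: 23 nM
Compound 2, `COc1ccccc1N1CCN(CCCCNC(=O)CCCc2ccccc2)CC1`: 84 nM

Going by the values given here, in an assay on frontal cortex for binding affinity to Adrenergic receptor alpha-1 (Rattus norvegicus), read by radioligand binding (a lower number here means a stronger inhibitor, a higher number a weaker inhibitor), compound 2 stands with the higher of the two numbers measured, and the one step known so far is a 3.7-fold higher number from compound 1 to compound 2 (0.56 log units; beyond the scatter), a modest rise beyond the scatter. Compound 3, `CCCCC(=O)NCCCCN1CCN(c2ccccc2OC)CC1`, differs from compound 2 by methyl in place of phenyl on a saturated chain carbon, three bonds along the chain from a carbonyl carbon. Among the compounds with values here, only that one step bears on this change: it also took an aromatic ring away from the amide side and weakened binding modestly. A modest rise in this assay is therefore expected, a 2.4-fold higher number from compound 2 to compound 3 (0.38 log units; beyond the scatter). Compound 3 is estimated at 200 nM, within a range from 80 nM to 600 nM.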

Compound 3, inhibition constant: 84 nM
Beside the measured number, compound 3's estimate is 2.4-fold (0.38 log units) above it, within the range that was stated.
By their numbers in this assay, from the lowest: compound 1; then compounds 2 and 3 (each within the scatter of the next).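

In this assay, methyl in place of phenyl at this place on the chain leaves the number unmoved (no change at the digits printed from compound 2 to compound 3 (within the scatter)), so the terminal aromatic ring of compound 2 carries no measurable weight here. The butyl amide still sits apart from the 4-aminobenzamide (a 3.7-fold higher number from compound 1 to compound 3 (0.56 log units; beyond the scatter)), and this gap matches the one seen with 3-phenylpropyl. Nothing available explains either result.

Whether the amino group of compound 1 or its ring on the carbonyl carbon accounts for that gap remains open. So does the effect of a propyl or hexyl chain, or of a terminal amine or carboxylic acid.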